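Dihydroxyphenyl in Place of Methylphenyl on the Hydrazone

The source may hold more compounds than are shown below. What is called first, only, known or untested is meant among the compounds shown, and "the series" means these compounds.

Measured compounds:
Compound 1 `NNC(=O)CSc1nnc(-c2ccncc2)o1` gives 3260 nM in a functional assay on HepG2 cells (Homo sapiens) for cytotoxicity, read by MTT assay, with a stated time of 48 h; a lower number here means a stronger inhibitor, a higher number a weaker inhibitor.
Compound 2 `Cc1ccc(/C=N/NC(=O)CSc2nnc(-c3ccncc3)o2)cc1` gives 10000 nM.
Compound 3 `O=C(CSc1nnc(-c2ccncc2)o1)N/N=C/c1cc(Br)ccc1O` gives 6490 nM.

Compound 2 carries the highest of the three numbers. Compound 3 sits within the scatter of it, while compound 1 lies at a lower number beyond the scatter. Compound 4 `O=C(CSc1nnc(-c2ccncc2)o1)N/N=C/c1ccc(O)c(O)c1` differs from compound 2 in one place: 3,4-dihydroxyphenyl in place of 4-methylphenyl on a carbon with a double bond to nitrogen. For the measured compounds named here, only one measured step bears on this, a change of the same group at the same place: a 1.5-fold lower number from compound 2 to compound 3 (0.19 log units; within the scatter). That step stayed within the scatter, so for compound 4 no step beyond the scatter is expected, with a slight lean to a lower number, as a 1.5-fold lower number from compound 2 to compound 4 (0.19 log units; within the scatter). The estimate for compound 4 is therefore 6500 nM, expected to fall between 2500 nM and 16000 nM.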

Compound 4, half-maximal inhibitory concentration: 760 nM
Compound 4: middle estimate off by 8.6-fold (0.93 log units), on the high side, and the stated range ends above it.
By their numbers in this assay, from the lowest: compound 4; then compounds 1, 3 and 2 (each within the scatter of the next, the first and the last beyond it).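

In this assay, the group on a carbon with a double bond to nitrogen proves able to shift the number well beyond the scatter: 3,4-dihydroxyphenyl gives a 13-fold lower number from compound 2 to compound 4 (1.12 log units; beyond the scatter) and also an 8.5-fold lower number from compound 3 to compound 4 (0.93 log units; beyond the scatter). The 5-bromo-2-hydroxyphenyl of compound 3 also carries a hydroxy group, so among these compounds a hydroxy group alone does not bring the large drop. Nothing available here explains the size of this change.

Still open, going by these compounds, is whether a phenyl with a single hydroxy group would keep the low number. Methoxy groups in place of both hydroxy groups also remain an open case.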